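This account rests on a few compounds, and the source may have more. Where it says the series, first, only, none or still open, it means among the compounds named here.

Measured in a functional assay on U-251 cells (Homo sapiens) for inhibition, read by colorimetric assay and sulforhodamine B assay, with a stated time of 48 h; on this read-out lower numbers stand for stronger inhibition of growth and higher numbers for weaker inhibition of growth:
- compound 1 `CCCCCCCCCCCC[C@@H](O)[C@H]1CC[C@H]([C@H](O)CCCCCCCCCCNC(=O)c2cccs2)O1` gives 2000 nM
- compound 2 `CCCCCCCCCCCC[C@@H](O)[C@H]1CC[C@H]([C@H](O)CCCCCCCCCCNC(=O)c2ccco2)O1` gives 100000 nM

For the measured compounds named here, compound 2 has the higher of the two numbers, with compound 1 as its only neighbour. The next compound is compound 3 `CCCCCCCCCCCC[C@@H](O)[C@H]1CC[C@H]([C@H](O)CCCCCCCCCCNC(=O)c2ccoc2)O1`, and the change is furan-3-yl in place of furan-2-yl on a carbonyl carbon.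

Going by the values given here, one measured step bears on this place: a 50-fold higher number from compound 1 to compound 2 (1.70 log units; beyond the scatter), a large step beyond the scatter. That step exchanged one ring for another, whereas here the atoms stay the same and are joined differently, so it gives no direct measure of the new change. Among the compounds with values here, it shows only that numbers in this assay can move far when the group on this carbonyl carbon changes.

Within the data shown here, no furan-3-yl compound has been measured yet. With compound 2 at 100000 nM as the high end of the series, a smaller move toward a lower number is expected, though no change beyond the scatter remains possible. The expected step is a 4.0-fold lower number from compound 2 to compound 3 (0.60 log units; beyond the scatter) (an estimate). Compound 3 is estimated at 25000 nM (expected range 3000 nM to 100000 nM).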

Compound 3, concentration for 50% growth inhibition: 100000 nM
For compound 3 the middle estimate is 4.0-fold (0.60 log units) below the measured one; low and high end bracket the measured number.
By their numbers in this assay, from the lowest: compound 1; then compounds 2 and 3 (each within the scatter of the next).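

In this assay the attachment point of the furan ring on the carbonyl carbon makes no visible difference (no change at the digits printed from compound 2 to compound 3 (within the scatter)), so furan-2-yl and furan-3-yl cannot be told apart at this position. The gap to the thiophen-2-yl amide now appears for both furan amides and not for one alone (a 50-fold higher number from compound 1 to compound 3 (1.70 log units; beyond the scatter)), which places compound 1 apart from compound 2 and compound 3 whichever way the furan ring is joined, a statement limited to these three compounds. Nothing at hand bears on why the thiophen-2-yl compound differs from the two furan compounds.

As far as these compounds go, it remains open whether the lower number of compound 1 belongs to thiophen-2-yl in particular or would also be reached with thiophen-3-yl, phenyl or pyridin-2-yl on the same carbonyl carbon. From the compounds shown here alone, it is also open whether the gap between the thiophene and furan amides would persist with a shorter or longer chain linking the amide nitrogen to the shared core.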